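Replacing methyl with amino near an assay limit

The source may hold more compounds than are shown below. What is called first, only, known or untested is meant among the compounds shown, and "the series" means these compounds.

In an ADME assay on Vero cells (Chlorocebus sabaeus) for cytotoxicity, with a stated time of 72 h (on this read-out lower numbers stand for stronger inhibition and higher numbers for weaker inhibition), compound 1 `CCOC(=O)c1cc(/C=C/c2ccccc2C(F)(F)F)on1` gives "not determined" (no result reported) and so adds nothing to the comparison. Compound 2 `CCOC(=O)c1cc(/C=C/c2cccc(C(C)C)c2)on1` stands at > 128000 nM as a limit of the assay and not as a number. Compound 3 `CCOC(=O)c1cc(/C=C/c2cccc(C)c2)on1` likewise stands at > 128000 nM in this assay and is therefore placed only by a limit.

Compound 4 `CCOC(=O)c1cc(/C=C/c2cccc(N)c2)on1` carries amino in place of methyl on an aromatic carbon, a change counted as amino in place of methyl on an aromatic carbon and sitting meta to a large group. Going by the values given here, the one measured step that bears on this is a step that the two limits leave unreadable from compound 2 to compound 3 with methyl in place of isopropyl, and its size cannot be read. The evidence is the limit of > 128000 nM in this assay, at which 2 of the 3 values shown sit, and no measured number lies inside that limit. Among the compounds with values here, no compound measured so far carries amino, so the data offer only a weak guide to this change. Compound 3 at > 128000 nM as a limit is the sole anchor, and no step beyond the usual scatter is expected in this assay for this change. The estimated step is a number no higher from compound 3 to compound 4 (the limit leaves the size open) and another limit is quite likely. Compound 4 is estimated at 128000 nM with an expected range from 50000 nM to 256000 nM for this read-out.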

Compound 4, half-maximal inhibitory concentration: > 128000 nM
Compound 4 was reported as a limit; the forecaster's own chance of this, stated with the estimate: 65%; the middle value sits exactly at the limit.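

Compound 4 gives > 128000 nM as a limit of the assay in this assay and not as a number. Going by these compounds alone, no step among compound 2, compound 3 and compound 4 can be read, because all three stand only at a limit: the limit of > 128000 nM in this assay, at which 3 of the 4 values shown sit. The compounds shown leave open whether amino, methyl and isopropyl on an aromatic carbon differ at all on this read-out.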